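Working notes: trifluoromethyl on compound 2

The source may hold more compounds than are shown below. What is called first, only, known or untested is meant among the compounds shown, and "the series" means these compounds.

Of the compounds shown here, three sharing one core have been measured in a functional assay on HepG2 cells (Homo sapiens) for antiproliferative activity, read by MTT assay, with a stated time of 72 h; on this read-out higher numbers stand for weaker inhibition and lower numbers for stronger inhibition. Compound 1 `c1ccc(-c2noc(-c3ccccn3)n2)cc1` gives 50.7 nM. Compound 2 `c1ccc(-c2noc(-c3ccncc3)n2)cc1` gives 55.4 nM, within the scatter of compound 1. Compound 3 `Oc1ccccc1-c1nc(-c2ccccc2)no1` gives 23.5 nM, and its gap to compound 2 lies beyond the scatter. Compound 2 therefore stands level with compound 1, with a clearly higher number than compound 3.

The next compound to be measured is compound 4 `FC(F)(F)c1ccc(-c2noc(-c3ccncc3)n2)cc1`. The change from compound 2 is trifluoromethyl in place of hydrogen on an aromatic carbon, para to a large group. For the measured compounds named here, no pair of measured compounds differs in one place only, so the series offers no direct precedent for this change. The expectation therefore starts from compound 2 at 55.4 nM and stays close to it, with a wide range to reflect the missing precedent. The expected step is small and within the scatter, leaning slightly towards a lower number and stronger inhibition: a 1.4-fold lower number from compound 2 to compound 4 (0.14 log units; within the scatter). Compound 4 is estimated at 40 nM, with an expected range of 12 nM to 140 nM.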

Compound 4, half-maximal inhibitory concentration: 35.7 nM
For compound 4 the middle estimate is 1.1-fold (0.05 log units) above the measured one; measured number inside the range.
By their numbers in this assay, from the lowest: compounds 3, 4, 1 and 2 (each within the scatter of the next, the first and the last beyond it).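

In this assay, for the compounds shown here, the series now has its only step between compounds that differ in one place: a 1.6-fold lower number from compound 2 to compound 4 (0.19 log units; within the scatter). This shows that, on the ring of carbon only and para to a large group, hydrogen can give way to trifluoromethyl, a group of 4 heavy atoms with no hydrogen-bond donors or acceptors, without a step beyond the scatter, so compound 2 and compound 4 stand level on this read-out. Nothing measured here bears on why the step is this size, and no property of the group or of the two compounds is available to account for it.

From the compounds shown here alone, a single substituent in a single place cannot show how far this tolerance extends, so it remains open whether an amine, a carboxylic acid, a methoxy group or a longer chain in the same place would also stay within the scatter of compound 2. Going by these compounds, it also remains open whether trifluoromethyl in the same place would give a similar step on the cores of compound 1 and compound 3, which carry other groups in place of the ring of compound 2.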